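The compounds below may be only part of what the source reports. "The series", "measured", "known", "first", "only" and "open" are said of these compounds alone.

Measured compounds:
- compound 1, `Cc1ccccc1-c1nc(CN2CCC(C(=O)NCCCN3CCC(C(C)C)CC3)CC2)c(C)o1`, 4280 nM
- compound 2, `Cc1oc(-c2c(Cl)cccc2Br)nc1CN1CCC(C(=O)NCCCN2C[C@H](C)C[C@H](C)C2)CC1`, 12200 nM

Of the compounds shown here, two have been measured in an ADME assay on Huh7.5.1 cells (Homo sapiens) for cytotoxicity, read by ATP content, with a stated time of 48 h; a higher number here means that more compound is tolerated, a lower number that less compound is tolerated. Compound 1 gives 4280 nM in this assay, the lowest of the two numbers, and compound 2 gives 12200 nM, a gap beyond the usual scatter. Among the measured compounds shown here, compound 2 differs from compound 1 in more than one place, so no single step between them is available, and their two values show only that compound 2 is the better tolerated of the pair.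

Compound 3, `Cc1ccccc1-c1nc(CN2CCC(C(=O)NCCN3C[C@H](C)C[C@H](C)C3)CC2)c(C)o1`, is not yet measured. It keeps the core of compound 1 and differs from it in one place: 3,5-dimethylpiperidin-1-yl in place of (4-isopropylpiperidin-1-yl)methyl on a saturated chain carbon, two bonds along the chain from an amide-type nitrogen. The group that enters is the same 3,5-dimethylpiperidin-1-yl found in compound 2, and the saturated chain from the amide-type nitrogen becomes one bond shorter. For the measured compounds named here, no measured step supports this exact change. Given only the two values shown, compound 3 is expected to sit close to compound 1, with a modest shift toward better tolerance, an expected step of a 1.4-fold higher number from compound 1 to compound 3 (0.15 log units; within the scatter) in this assay. The estimate for compound 3 is therefore 6000 nM, within 2500 nM to 15000 nM.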

Compound 3, half-maximal cytotoxic concentration: 24400 nM
Compound 3: the middle estimate sits 4.1-fold (0.61 log units) below what was measured; measured number above the stated range.
By their numbers in this assay, from the lowest: compound 1; then compounds 2 and 3 (each within the scatter of the next).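

In this assay, 3,5-dimethylpiperidin-1-yl in place of (4-isopropylpiperidin-1-yl)methyl on a saturated chain carbon, two bonds along the chain from an amide-type nitrogen, gives a 5.7-fold higher number from compound 1 to compound 3 (0.76 log units; beyond the scatter). Among the compounds shown here, this is the first single-place comparison, and it shows that tolerance on the core of compound 1 responds to a change at this end of the chain, which the multi-place difference between compound 1 and compound 2 could not show. Cut one bond further out, the same difference reads 2-(4-isopropylpiperidin-1-yl)ethyl to (3,5-dimethylpiperidin-1-yl)methyl, so the ring substitution and the chain length change together, and no measurement shown accounts for the higher number.

The compounds shown leave open how much of the step belongs to the ring substitution and how much to the chain length, as neither change appears alone. They also leave open how an unsubstituted piperidine, a morpholine or a longer chain at this position would behave in this assay.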